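Hydroxymethyl on the Side Chain of a Diarylmethane

This account rests on a few compounds, and the source may have more. Where it says the series, first, only, none or still open, it means among the compounds named here.

Compound 1 `COC[C@H](C(C)C)C(c1ccc(O)c(OC)c1)c1ccc(O)c(OC)c1` was tested in a functional assay on HL-60 cells (Homo sapiens) for cytotoxicity, read by WST assay, with a stated time of 48 h (a higher number here means a weaker inhibitor, a lower number a stronger inhibitor), where compound 1 gives 72000 nM. This is the higher of the two plain numbers shown: compound 2 `COc1cc(C(c2ccc(O)c(OC)c2)[C@H](CC(C)C)C(C)C)ccc1O` gives 9600 nM, and the step of a 7.5-fold lower number from compound 1 to compound 2 (0.88 log units; beyond the scatter). Compound 3 `COc1cc(C(c2ccc(O)c(OC)c2)[C@@H](CO)C(C)C)ccc1O` reaches only a limit of the assay, > 100000 nM. The step of an at least 1.3-fold higher number from compound 1 to compound 3 (0.14 log units; that floor lies within the scatter) and the step of an at least 10-fold higher number from compound 2 to compound 3 (1.01 log units; beyond the scatter) both end at that limit (the limit of > 100000 nM in this assay, at which 1 of the 3 values shown sits).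

Compound 4 `COc1cc(C(c2ccc(O)c(OC)c2)[C@H](C)[C@@H](C)CO)ccc1O` differs from compound 1 in one place: 2-(hydroxymethyl)-1-methylpropyl in place of 1-(methoxymethyl)-2-methylpropyl on a saturated chain carbon bound to two aromatic carbons. As in compound 3, the side chain of compound 4 carries a free hydroxyl where compound 1 carries a methoxy. The step of an at least 1.3-fold higher number from compound 1 to compound 3 (0.14 log units; that floor lies within the scatter) bears most directly on this change; its floor lies within the scatter, while the step of an at least 10-fold higher number from compound 2 to compound 3 (1.01 log units; beyond the scatter) was large. On these data alone, an upward step is therefore expected, most likely ending at a limit, though its size remains open. The estimate for compound 4 in this assay is 120000 nM, with a range from 50000 nM to 300000 nM. This expected value for compound 4 corresponds to a 1.7-fold higher number from compound 1 to compound 4 (0.22 log units; within the scatter).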

Compound 4, half-maximal inhibitory concentration: > 100000 nM
Compound 4: no number, only a limit (the forecaster's own chance of this, stated with the estimate: 60%); the middle value lies beyond the limit too.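

Replacing the 1-(methoxymethyl)-2-methylpropyl of compound 1 with 2-(hydroxymethyl)-1-methylpropyl gives an at least 1.3-fold higher number from compound 1 to compound 4 (0.14 log units; that floor lies within the scatter), so this comparison alone does not establish a real change. Against the hydroxyl-free 1-isopropyl-3-methylbutyl chain of compound 2, the result is clearer: an at least 10-fold higher number from compound 2 to compound 4 (1.01 log units; beyond the scatter). Compound 3 and compound 4 both carry a free hydroxyl on the side chain and both end at a limit in this assay, so the step between them cannot be read and their two chains cannot be ranked: the limit of > 100000 nM in this assay, at which 2 of the 4 values shown sit.

Compound 4 differs from compound 2 in both chain size and the presence of a hydroxyl, so the shift cannot be assigned to either one alone. On these data alone, whether an amine in place of the hydroxyl, or a longer chain ending in a hydroxyl, would move the number toward that of compound 2 remains open.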